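Clearance after swapping cyclohexyl for pyridin-2-yl

The compounds below may be only part of what the source reports. "The series", "measured", "known", "first", "only" and "open" are said of these compounds alone.

Measured so far in an ADME assay (liver) for metabolic stability, with Liver microsome (Rattus norvegicus) as the target, using microsomes and NADPH, with a stated time of 30 min, at 37 degrees C, tested at 1 uM; on this read-out lower numbers stand for slow clearance and higher numbers for fast clearance:
Compound 1 (`CC(O)(c1ccc(N2CCN(S(=O)(=O)c3ccc(N)nc3)CC2)cc1)C(F)(F)F`) gives < 14 mL.min-1.g-1 as a limit of the assay, not a number.
Compound 2 (`CC(O)(c1ccc(-c2ccc(S(=O)(=O)c3ccc(N)nc3)nc2NC2CCCCC2)nc1)C(F)(F)F`) gives 280 mL.min-1.g-1 as a true number.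

Within the data shown here, compound 2 holds the only true number here, and its only comparison is a limit. Compound 3 (`CC(O)(c1ccc(-c2ccc(S(=O)(=O)c3ccc(N)nc3)nc2Nc2ccccn2)nc1)C(F)(F)F`) is not yet measured. It carries pyridin-2-yl in place of cyclohexyl on a nitrogen on an aromatic ring, and the rest of the molecule stays the same. Among the measured compounds shown here, no measured pair shows this change, so any forecast is a judgement. Compound 2 at 280 mL.min-1.g-1 leaves plenty of room downward, so a fall in intrinsic clearance is expected. The estimated step is a 2.8-fold lower number from compound 2 to compound 3 (0.45 log units; beyond the scatter) in this assay. For compound 3 the estimated value is 100 mL.min-1.g-1, within a range of 35 mL.min-1.g-1 to 250 mL.min-1.g-1 when measured.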

Compound 3, intrinsic clearance in microsomes: 130 mL.min-1.g-1
The estimate for compound 3 lay 1.3-fold (0.11 log units) below the measured number; the range from low to high includes it.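

At the nitrogen on an aromatic ring, the group attached clearly affects this assay: pyridin-2-yl in place of cyclohexyl gives a 2.2-fold lower number from compound 2 to compound 3 (0.33 log units; beyond the scatter). This is the first single change that can be read among the compounds shown, and the two groups have the same count of heavy atoms, so the step does not come with a larger group; the swap replaces a ring of carbon only with an aromatic ring holding one hetero atom and adds a hydrogen-bond acceptor. Nothing measured here explains why the number falls.

A phenyl group on the same nitrogen would show whether the aromatic ring alone accounts for the step, or whether its ring nitrogen is also needed. On these data alone, it also remains open whether a small methyl group there would give a lower or a higher number.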